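A few compounds are considered here, and "the series" means these few. Any claim that something is new, unique, unknown or untested is made for them only; others in the source may bear on it.

- Compound 1 `O=C(c1ccccc1)N(N=C1C(Cl)=C(Cl)C(Cl)=C1Cl)C(=O)c1ccccc1`: 2000 nM
- Compound 2 `FC(F)(F)c1cccc(NN=C2C(Cl)=C(Cl)C(Cl)=C2Cl)c1`: 1000 nM
- Compound 3 `CC(C)(C)NN=C1C(Cl)=C(Cl)C(Cl)=C1Cl`: > 3000 nM (a limit)

All three compounds were tested in a functional assay on MM1.S cells (Homo sapiens) for cytotoxicity, read by MTT assay, with a stated time of 48 h; a higher number here means a weaker inhibitor, a lower number a stronger inhibitor. Compound 2 gives 1000 nM and compound 1 gives 2000 nM, and these two numbers lie within the usual scatter of each other. Compound 2 therefore shares the best measured position with compound 1, and the two cannot be separated. Compound 3 reaches only a limit of the assay (> 3000 nM).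

Compound 4 `Fc1cccc(NN=C2C(Cl)=C(Cl)C(Cl)=C2Cl)c1` has not yet been measured. It differs from compound 2 in one place (fluoro in place of trifluoromethyl on an aromatic carbon), with fluoro in place of trifluoromethyl on an aromatic carbon, meta to a large group. Among the compounds with values here, no two measured compounds differ in only one place, so the data give no direct measure of what such a change does. The expectation therefore rests on compound 2 (1000 nM) as the closest measured relative. No change beyond the scatter is expected, and the estimated step is small (a 1.3-fold higher number from compound 2 to compound 4 (0.11 log units; within the scatter)). For compound 4 the estimated value is 1300 nM, with an expected range from 500 nM to 3000 nM.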

Compound 4, half-maximal inhibitory concentration: 1500 nM
For compound 4 the middle estimate is 1.2-fold (0.06 log units) below the measured one, and the stated range covers the measured number.
By their numbers in this assay, from the lowest: compounds 2, 4 and 1 (each within the scatter of the next). At a limit, above all of these: compound 3.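

In this assay, within the data shown here, the exchange of trifluoromethyl for fluoro on the aromatic carbon gives a 1.5-fold higher number from compound 2 to compound 4 (0.18 log units; within the scatter) and provides the first direct comparison of two compounds that differ in only one place. The group that leaves has 4 heavy atoms and the group that enters has 1 heavy atom, yet compound 2 and compound 4 cannot be separated in this measurement, which shows that the full trifluoromethyl group is not required on this carbon to keep the number in this range. No available measurement bears on what lies behind the size of this step.

Going by these compounds, it remains open whether other groups on the same carbon, such as an amine, a carboxylic acid or a methoxy group, would leave the number within the scatter or move it beyond. On these data alone, it is also open whether the exchange of trifluoromethyl for fluoro would give a similar step on another carbon of the aromatic ring, as this single pair speaks only for the one place.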